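Swapping the piperidine side chain of a tryptamine-derived ligand

The source may hold more compounds than are shown below. What is called first, only, known or untested is meant among the compounds shown, and "the series" means these compounds.

Of the compounds shown here, three sharing one core have been measured in an assay on CHO cells for displacement of a labelled ligand from 5-hydroxytryptamine receptor 1B (Homo sapiens); a lower number here means a stronger inhibitor, a higher number a weaker inhibitor. Compound 1 `C[C@@H](NCC1CCN(CCCc2c[nH]c3ccc(-n4cnnc4)cc23)CC1)c1ccccc1` gives 14 nM, the lowest of the three numbers. Compound 2 `OC[C@H](NC1CCN(CCCc2c[nH]c3ccc(-n4ccnc4)cc23)CC1)c1ccccc1` gives 100 nM, and compound 3 `OC[C@H](NC1CCN(CCCc2c[nH]c3ccc(Cn4cncn4)cc23)CC1)c1ccccc1` gives 1300 nM. Among the measured compounds shown here, compound 1 and compound 2 differ in more than one place, so their two values show only that compound 1 is the stronger binder of the pair. For the measured compounds named here, the one single-point step among them, a 13-fold higher number from compound 2 to compound 3 (1.11 log units; beyond the scatter), concerns the group on the aromatic carbon of the core and not the side chain attached to the saturated ring.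

The new compound 4 `CC(C)=CCN(C)C1CCN(CCCc2c[nH]c3ccc(-n4cnnc4)cc23)CC1` differs from compound 1 in exactly that side chain: methyl(3-methylbut-2-en-1-yl)amino in place of ((1-phenylethyl)amino)methyl on a saturated ring carbon. The aromatic ring and the hydrogen-bond donor of the leaving group are gone, and a branched chain with a double bond takes their place. Going by the values given here, no measured step touches this part of the molecule, so the direction and size of the effect cannot be read from the data. On balance a weakening of binding is expected, of the size a 4.3-fold higher number from compound 1 to compound 4 (0.63 log units; beyond the scatter). Compound 4 is therefore estimated to give 60 nM in this assay, with a plausible range from 12 nM to 300 nM.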

Compound 4, half-maximal inhibitory concentration: 41 nM
Beside the measured number, compound 4's estimate is 1.5-fold (0.17 log units) above it; low and high end bracket the measured number.
By their numbers in this assay, from the lowest: compound 1; then compound 4; then compound 2; then compound 3.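

Among the compounds shown here, this is the first measured step at the saturated ring carbon that carries the side chain, and in this assay it reads a 2.9-fold higher number from compound 1 to compound 4 (0.47 log units; beyond the scatter) and counts as modest. The swap removes the six-membered aromatic ring of carbon only, the one hydrogen-bond donor and the one defined stereocentre of ((1-phenylethyl)amino)methyl all at once, yet compound 4 still gives 41 nM as a binder with methyl(3-methylbut-2-en-1-yl)amino in their place, so at this position, for this pair, binding in the nanomolar range does not depend on keeping that aromatic ring or that donor. No measurement here explains the size of the step, and it remains one combined result for all the features that changed together.

The compounds shown leave open which of the lost features accounts for the step, and a benzylamino group on the same ring carbon would keep an aromatic ring and a donor while dropping the stereocentre. A smaller dimethylamino group or a cyclohexylamino group there would likewise show how much of the side chain this position needs.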